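The source may report more compounds than this note shows. Statements on the series, on what has been measured and on what is new or still open speak of the compounds shown alone.

Measured in an ADME assay on A549 cells (Homo sapiens) for cytotoxicity, read by MTT assay, with a stated time of 72 h; a lower number here means a stronger inhibitor, a higher number a weaker inhibitor:

Compound 1 `CC(=O)N1N=C(c2ccc(-n3c(C)ccc3C)cc2)OC1c1ccccc1Cl` gives 206000 nM.
Compound 2 `CC(=O)N1N=C(c2ccc(-n3c(C)ccc3C)cc2)OC1c1ccccc1[N+](=O)[O-]` gives 182000 nM.
Compound 3 `O=[N+]([O-])c1ccc(-c2nnc(-c3ccc(-n4cccc4)cc3)o2)cc1` gives 258000 nM.

Compound 4 `Clc1ccc(-c2nnc(-c3ccc(-n4cccc4)cc3)o2)cc1` is not yet measured. Compound 1 and compound 2 share one core, compound 3 and compound 4 another, and the difference between the two cores is not broken down here. Within each pair the change is the same kind: chloro in place of nitro on an aromatic carbon and (chloro in place of nitro on an aromatic carbon). The surroundings differ, though: in compound 1 the chloro sits ortho to a large group, in compound 4 para to a large group, so the two changes are alike but not the same. The earlier step was a 1.1-fold higher number from compound 2 to compound 1 (0.05 log units; within the scatter). Compound 3 and compound 2 lie within the scatter of each other. Compound 4 is therefore expected to show a 1.1-fold higher number from compound 3 to compound 4 (0.04 log units; within the scatter) in this assay. That expectation rests on the earlier step, a 1.1-fold higher number from compound 2 to compound 1 (0.05 log units; within the scatter). The estimate for compound 4 is 280000 nM, from 150000 nM to 520000 nM.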

Compound 4, half-maximal inhibitory concentration: 256000 nM
Compound 4: middle estimate off by 1.1-fold (0.04 log units), on the high side; low and high end bracket the measured number.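

In this assay, chloro in place of nitro gives a 1.0-fold lower number from compound 3 to compound 4 (0.00 log units; within the scatter). Set beside the same change on the other core, this step shows that the change carries across these two cores with no difference that can be told apart from the scatter: the same change on two cores in this assay, a 1.1-fold higher number (0.05 log units; within the scatter) from compound 2 to compound 1 and a 1.0-fold lower number (0.00 log units; within the scatter) from compound 3 to compound 4, 1.1-fold (0.06 log units) apart, within the scatter of two such steps

Within the data shown here, this does not show that the change would behave alike on any other core, since it rests on only two pairs and a real difference smaller than the scatter would go unseen. 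

Going by these compounds, it remains open whether an amine or a carboxylic acid on that aromatic carbon would give a number beyond the scatter from those of compound 3 and compound 4.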